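Shortening and Branching the Amide Chain: Compound 4

This account rests on a few compounds, and the source may have more. Where it says the series, first, only, none or still open, it means among the compounds named here.

Three measured compounds share one core and differ only in the chain attached to the amide carbonyl. Compound 1 `CCC(=O)Nc1ccc(S(=O)(=O)Oc2ccccc2I)cc1` has the shortest chain, compound 2 `CCCC(=O)Nc1ccc(S(=O)(=O)Oc2ccccc2I)cc1` the next, and compound 3 `CCCCCC(=O)Nc1ccc(S(=O)(=O)Oc2ccccc2I)cc1` the longest. In a functional assay on HT-1080 cells (Homo sapiens) for antiproliferative activity, read by sulforhodamine B assay, with a stated time of 48 h (a higher number here means a weaker inhibitor, a lower number a stronger inhibitor), compound 1 gives 7200 nM. In this assay compound 2 gives 2000 nM. In this assay compound 3 gives 9600 nM, the highest number of the three. Its distance from compound 1 is small: a 1.3-fold higher number from compound 1 to compound 3 (0.12 log units; within the scatter). Its distance from compound 2 is larger: a 4.8-fold higher number from compound 2 to compound 3 (0.68 log units; beyond the scatter). Compound 4 `CC(C)(C)C(=O)Nc1ccc(S(=O)(=O)Oc2ccccc2I)cc1` is the next member. The change from compound 3 is tert-butyl in place of pentyl on a carbonyl carbon, so a four-carbon branched group replaces a five-carbon straight chain. For the measured compounds named here, the step from compound 2 to compound 3 shows that lengthening the chain by two carbons raised the number, and compound 4 moves back toward a four-carbon group, but no measured step tests branching. A modest lowering is therefore expected, a 2.1-fold lower number from compound 3 to compound 4 (0.33 log units; beyond the scatter), with wide uncertainty. For compound 4 in this assay the estimate is 4500 nM, expected to lie between 1500 nM and 14000 nM.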

Compound 4, half-maximal inhibitory concentration: 2600 nM
Compound 4: middle estimate off by 1.7-fold (0.24 log units), on the high side, and the stated range covers the measured number.
By their numbers in this assay, from the lowest: compounds 2 and 4 (each within the scatter of the next); then compounds 1 and 3 (each within the scatter of the next).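

For the compounds shown here, the tert-butyl group shows that a branched chain on this carbonyl carbon is accepted in this assay, and it is the first group here to bring the number back down from the high end of the series (with a 3.7-fold lower number from compound 3 to compound 4 (0.57 log units; beyond the scatter) and a 2.8-fold lower number from compound 1 to compound 4 (0.44 log units; beyond the scatter)). Compound 4 and compound 2 cannot be told apart (with a 1.3-fold higher number from compound 2 to compound 4 (0.11 log units; within the scatter), a gap within the scatter), so the low numbers in this small set are not confined to the straight propyl chain of compound 2. Going by these compounds alone, the earlier compounds suggested that only one straight chain length gave a low number, with ethyl in compound 1 and pentyl in compound 3 both higher than propyl, whereas compound 4 shows that a branched group can match that result and that a straight chain is not required at this position.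

From the compounds shown here alone, whether an isopropyl group, a cyclohexyl ring or a chain ending in an amine on the same carbonyl carbon would join compound 2 and compound 4 remains open. Nothing available here explains why tert-butyl and propyl give such similar numbers while pentyl and ethyl do not.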